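Swapping 2,5-dihydroxyphenyl for 4-bromophenyl on the shared core

The source may report more compounds than this note shows. Statements on the series, on what has been measured and on what is new or still open speak of the compounds shown alone.

In a functional assay on MCF7 cells (Homo sapiens) for inhibition, read by MTT assay, with a stated time of 72 h (a higher number here means a weaker inhibitor, a lower number a stronger inhibitor), compound 1 `COc1cc(OC)c(OC)cc1/C=C/C(=O)c1ccc(Cl)cc1` gives 29500 nM. Compound 2 `COc1cc(OC)c(OC)cc1/C=C/C(=O)c1ccc(-c2c[nH]cn2)cc1` gives > 150000 nM, which is a limit of the assay. Compound 3 `COc1cc(OC)c(OC)cc1/C=C/C(=O)c1cc(O)ccc1O` gives > 150000 nM, which is also a limit and not a number. Compound 4 `COc1cc(OC)c(OC)cc1/C=C/C(=O)c1ccc(Br)cc1` differs from it by 4-bromophenyl in place of 2,5-dihydroxyphenyl on a carbonyl carbon, with 4-bromophenyl in place of 2,5-dihydroxyphenyl on a carbonyl carbon. The closest measured change is an at least 5.0-fold higher number from compound 1 to compound 3 (0.70 log units; beyond the scatter), which runs the opposite way and starts from 4-chlorophenyl. A second change at that group, an at least 5.0-fold higher number from compound 1 to compound 2 (0.70 log units; beyond the scatter), points the same way. The expected step is therefore a clear fall in the number in this assay, namely an at least 5.3-fold lower number from compound 3 to compound 4 (0.72 log units; beyond the scatter). Compound 4 is estimated at 28000 nM, within a range of 11000 nM to 70000 nM.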

Compound 4, half-maximal inhibitory concentration: 18300 nM
Compound 4: middle estimate off by 1.5-fold (0.18 log units), on the high side; low and high end bracket the measured number.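

In this assay, 4-bromophenyl in place of 2,5-dihydroxyphenyl on the carbonyl carbon gives an at least 8.1-fold lower number from compound 3 to compound 4 (0.91 log units; beyond the scatter), and bromo in place of 1H-imidazol-4-yl gives an at least 8.1-fold lower number from compound 2 to compound 4 (0.91 log units; beyond the scatter). Both steps start from a value that is a limit and not a number: the limit of > 150000 nM in this assay, at which 2 of the 4 values shown sit. Bromo and chloro on the aromatic carbon do not separate, at a 1.6-fold lower number from compound 1 to compound 4 (0.21 log units; within the scatter), so the level seen with chloro is also reached with a second halogen. From the compounds shown here alone, whether an amine or a carboxylic acid on that aromatic carbon would stay at this level remains open.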